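Pyrazole series: methoxy to hydroxy on compound 3

The compounds below may be only part of what the source reports. "The series", "measured", "known", "first", "only" and "open" are said of these compounds alone.

Working notes on three measured compounds and one open one. In a functional assay on LOX IMVI cells (Homo sapiens) for cytotoxicity, read by sulforhodamine B assay, with a stated time of 48 h, tested at 10 uM (a lower number here means a stronger effect, a higher number a weaker effect of the compound at the concentration tested), compound 1 `COc1cc(C)cc(-c2c(-c3ccnc(-c4ccc(C(C)=O)cc4)c3)cnn2CC#N)c1` gives 21%, compound 2 `Cc1cc(O)cc(-c2nn(CC#N)cc2-c2ccnc(-c3ccc(Oc4ccccc4)cc3)c2)c1` gives -86%, and compound 3 `COc1cc(C)cc(-c2nn(CC#N)cc2-c2ccnc(-c3ccc(N(C)C)cc3)c2)c1` gives -23%. Compound 3 therefore stands second highest of the three numbers: compound 1 sits higher by a margin beyond the scatter, and compound 2 sits lower by a margin that is also beyond the scatter.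

Compound 4 `Cc1cc(O)cc(-c2nn(CC#N)cc2-c2ccnc(-c3ccc(N(C)C)cc3)c2)c1` is not yet measured. It differs from compound 3 in one place: hydrogen in place of methyl on an oxygen on an aromatic ring. Going by the values given here, no pair of measured compounds differs by this change alone, so no direct step is available. Among the compounds with values here, compound 2, which carries the 3-hydroxy-5-methylphenyl group together with a different remote substituent, shows the lowest number of the three, while the two methoxy compounds show the two higher numbers; with only three compounds this is no more than a hint.

The step from compound 3 to compound 4 is expected to be modest and downward, a number 17 percentage points lower from compound 3 to compound 4 (beyond the scatter), and may not exceed the scatter. For compound 4 the estimate in this assay is -40%, within a range from -80% to 0%.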

Compound 4, a percentage reported as activity, at one concentration (the size of the read-out at that concentration, not a potency): -87%
For compound 4 the middle estimate is 47 percentage points above the measured one; measured number below the stated range.
By their numbers in this assay, from the lowest: compounds 4 and 2 (each within the scatter of the next); then compound 3; then compound 1.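

Going by these compounds alone, the methoxy to hydroxy change now has a direct reading: in this assay it gives a number 64 percentage points lower from compound 3 to compound 4 (beyond the scatter) and is a large step, where the earlier compounds offered only a hint. With the 3-hydroxy-5-methylphenyl group in place, dimethylamino in place of phenoxy on an aromatic carbon gives a number 1 percentage points lower from compound 2 to compound 4 (within the scatter) and leaves no visible difference, so this pair does not separate those two remote groups. Nothing at hand accounts for the size of the step from methoxy to hydroxy.

The compounds shown leave open whether the same change holds on the core of compound 1, which carries an acetyl group on its remote ring. They also leave open how an ethoxy group, an amine or a carboxylic acid would read on that oxygen-bearing carbon in place of the hydroxy group.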